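The compounds below may be only part of what the source reports. "The series", "measured", "known", "first", "only" and "open" are said of these compounds alone.

Of the compounds shown here, two sharing one core have been measured in a functional assay (aorta) with Oryctolagus cuniculus as the target; a higher number here means weaker binding, a lower number tighter binding. Compound 1 (`COc1cc(OCCCN2CCC(C(c3ccc(F)cc3)c3ccc(F)cc3)CC2)ccc1C(C)=O`) carries a 4-acetyl-3-methoxyphenyl group on an oxygen on a saturated carbon and gives 3.16 nM. Compound 2 (`Nc1ccc(OCCCN2CCC(C(c3ccc(F)cc3)c3ccc(F)cc3)CC2)cc1`) carries a 4-aminophenyl group in that place and gives 31.6 nM, the higher of the two numbers. Among the compounds with values here, the only measured step is a 10-fold higher number from compound 1 to compound 2 (1.00 log units; beyond the scatter).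

Compound 3 (`CC(=O)Nc1ccc(OCCCN2CCC(C(c3ccc(F)cc3)c3ccc(F)cc3)CC2)cc1`) is compound 2 with acetyl in place of hydrogen on a nitrogen on an aromatic ring, so that 4-aminophenyl becomes 4-acetamidophenyl: acetyl in place of hydrogen on a nitrogen on an aromatic ring. Within the data shown here, no measured step shows this change directly. The step to compound 2 bears on it only loosely, since compound 1 also has an acetyl group, though not on a nitrogen, and differs from compound 2 by more than that group. Read in reverse, a 10-fold higher number from compound 1 to compound 2 (1.00 log units; beyond the scatter) suggests a move toward a lower number in this assay, probably a smaller one than that step. The expected step is a 2.6-fold lower number from compound 2 to compound 3 (0.42 log units; beyond the scatter). For compound 3 the estimated value is 12 nM, within an expected range of 3.5 nM to 40 nM.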

Compound 3, dissociation constant: 12.6 nM
For compound 3 the middle estimate is 1.1-fold (0.02 log units) below the measured one; low and high end bracket the measured number.
By their numbers in this assay, from the lowest: compound 1; then compound 3; then compound 2.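

Within this assay, the step of a 2.5-fold lower number from compound 2 to compound 3 (0.40 log units; beyond the scatter) gives the first direct reading of acetyl in place of hydrogen on a nitrogen on an aromatic ring, showing that this change on its own moves the number downward. The change closes only part of the gap to the 4-acetyl-3-methoxyphenyl group, since a 4.0-fold higher number from compound 1 to compound 3 (0.60 log units; beyond the scatter) still separates 4-acetamidophenyl from it, which places compound 3 between compound 1 and compound 2 in this assay. Nothing available here accounts for either step.

The step between 4-acetamidophenyl and 4-acetyl-3-methoxyphenyl changes several features together, so the compounds shown cannot separate the contribution of the methoxy group from that of acetyl standing on the ring directly rather than on nitrogen; a phenyl group carrying acetyl alone would bear on that question. Also open, going by these compounds, is whether the lower number is particular to acetyl on the nitrogen or would extend to other groups there, such as propanoyl, methanesulfonyl or a urea.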